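Trading the Urea Arm for a Plain Phenyl

The source may hold more compounds than are shown below. What is called first, only, known or untested is meant among the compounds shown, and "the series" means these compounds.

For the measured compounds named here, compound 2 `COc1cc(-c2nn(-c3cccc(NC(=O)Nc4cccc(C(F)(F)F)c4)c3)cc2-c2ccncc2)ccc1Cl` stands lowest of the two numbers so far in a functional assay on TK-10 cells (Homo sapiens) for inhibition, read by sulforhodamine B assay, with a stated time of 48 h (a higher number here means a weaker inhibitor of growth, a lower number a stronger inhibitor of growth), where compound 2 gives 1310 nM. Its nearest neighbour is compound 1 `O=C(Nc1cccc(-n2cc(-c3ccncc3)c(-c3ccc(Cl)c(O)c3)n2)c1)Nc1cccc(C(F)(F)F)c1`, which in this assay gives 2120 nM; the step of a 1.6-fold lower number from compound 1 to compound 2 (0.21 log units; within the scatter) is within the scatter, so the two compounds cannot be told apart on these numbers.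

Compound 3 `COc1cc(-c2nn(-c3cccc(NC(=O)c4ccccc4)c3)cc2-c2ccncc2)ccc1Cl` differs from compound 2 by phenyl in place of (3-(trifluoromethyl)phenyl)amino on a carbonyl carbon. One hydrogen-bond donor leaves with the (3-(trifluoromethyl)phenyl)amino group, and the carbonyl carbon keeps only its amide-type nitrogen and the new phenyl.

Going by the values given here, no measured step bears on this change. Among the compounds with values here, the single step known, from compound 1 to compound 2, concerns the oxygen on an aromatic ring and leaves the carbonyl untouched, so it gives no guidance on what the exchange at the carbonyl carbon does in this assay. The expectation therefore rests only on the size of the change: a sizeable part of compound 2 is removed, and a weaker inhibitor of growth is expected, with the step of a 4.6-fold higher number from compound 2 to compound 3 (0.66 log units; beyond the scatter). For compound 3 the estimated value in this assay is 6000 nM, within a range from 1500 nM to 25000 nM.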

Compound 3, concentration for 50% growth inhibition: 7000 nM
Estimate against measurement, compound 3: 1.2-fold (0.07 log units) below; measured number inside the range.
By their numbers in this assay, from the lowest: compounds 2 and 1 (each within the scatter of the next); then compound 3.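

For the compounds shown here, this is the first step that rises above the noise: a 5.3-fold higher number from compound 2 to compound 3 (0.73 log units; beyond the scatter) in this assay. The earlier pair differed only at the oxygen on an aromatic ring and could not be told apart, whereas this change on the carbonyl carbon gives a clear move towards weaker inhibition of growth, so the group held there does affect the read-out. Nothing shown here accounts for that loss, and no supporting measurement explains why replacing the larger (3-(trifluoromethyl)phenyl)amino group with phenyl has this result.

Several things leave in this single exchange: the amino nitrogen with its hydrogen-bond donor, and the trifluoromethyl group, so the compounds shown cannot assign the change to either part, and a plain phenylamino group or a phenyl carrying trifluoromethyl on the same carbonyl carbon would separate the two. Also open, from the compounds shown here alone, is how much of the aromatic ring this position needs, which a small group such as methyl or a saturated ring such as morpholine on that carbonyl carbon would begin to address.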